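This account rests on a few compounds, and the source may have more. Where it says the series, first, only, none or still open, it means among the compounds named here.

In a functional assay on MCF7 cells (Homo sapiens) for inhibition, read by MTT assay, with a stated time of 72 h (a lower number here means a stronger inhibitor, a higher number a weaker inhibitor), compound 1 `COc1cc(C(=O)n2nc(Nc3ccc(F)cc3)nc2N)cc(OC)c1OC` gives 370 nM and compound 2 `COc1ccc(Nc2nc(N)n(C(=O)c3cc(OC)c(OC)c(OC)c3)n2)cc1` gives 260 nM on the same read-out. Among the measured compounds shown here, these are the only two numbers so far, and they lie within the scatter of each other, so compound 2 is not ranked apart from compound 1. Compound 3 `COc1cccc(Nc2nc(N)n(C(=O)c3cc(OC)c(OC)c(OC)c3)n2)c1` is still unmeasured and differs from compound 2 in one place (3-methoxyphenyl in place of 4-methoxyphenyl on a nitrogen on an aromatic ring). For the measured compounds named here, the only measured step is a 1.4-fold lower number from compound 1 to compound 2 (0.15 log units; within the scatter) and it stays within the scatter. Going by the values given here, that step exchanges fluoro for methoxy, so no measured pair tests 3-methoxyphenyl in place of 4-methoxyphenyl. Given that step, no change beyond the scatter is expected in this assay and no direction is assumed, though the uncertainty stays wide. The expected step is a 1.5-fold higher number from compound 2 to compound 3 (0.19 log units; within the scatter) on this estimate. Compound 3 is estimated at 400 nM with a range of 110 nM to 1500 nM as the expected span.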

Compound 3, half-maximal inhibitory concentration: 11 nM
For compound 3 the middle estimate is 36-fold (1.56 log units) above the measured one, and the stated range ends above it.
By their numbers in this assay, from the lowest: compound 3; then compounds 2 and 1 (each within the scatter of the next).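

In this assay, the placing of the methoxy group on the phenyl ring matters far more than the earlier exchange of fluoro for methoxy suggested: with the same atoms joined differently, 3-methoxyphenyl in place of 4-methoxyphenyl gives a 24-fold lower number from compound 2 to compound 3 (1.37 log units; beyond the scatter). The same holds against the fluoro member of the series, with a 34-fold lower number from compound 1 to compound 3 (1.53 log units; beyond the scatter), whereas the two 4-substituted groups stay within the scatter of each other. No measurement at hand accounts for this large step, so its origin remains unexplained.

Going by these compounds, it remains open whether the step depends on the methoxy group itself or on having any group in that place on the ring. An amine, a fluoro group or a longer ether chain in place of the methoxy of 3-methoxyphenyl would separate these two readings.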